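This account rests on a few compounds, and the source may have more. Where it says the series, first, only, none or still open, it means among the compounds named here.

Measured so far:
- compound 1 `CC1(Cc2ccccc2)CC(S(=O)(=O)c2cccc(F)c2)=C(c2ccc(/C(N)=N\O)cc2)O1`: 59600 nM
- compound 2 `CC1(c2ccc(-c3ccc(/C(N)=N\O)cc3)cc2)CC(S(=O)(=O)c2ccc(F)cc2)=C(c2ccc(/C(N)=N\O)cc2)O1`: 15300 nM
- compound 3 `CC1(Cc2ccccc2)CC(S(=O)(=O)c2ccccc2F)=C(c2ccc(/C(N)=N\O)cc2)O1`: 61700 nM

In an ADME assay on HepG2 cells (Homo sapiens) for cytotoxicity, read by MTT assay, with a stated time of 72 h (on this read-out lower numbers stand for higher toxicity in this test and higher numbers for lower toxicity in this test), compound 2 gives the lowest number of the three, and both of its neighbours stand beyond the scatter from it, so compound 2 is the most toxic of the measured set. Compound 4 `CC1(c2ccc(Br)cc2)CC(S(=O)(=O)c2ccc(F)cc2)=C(c2ccc(/C(N)=N\O)cc2)O1` is not yet measured. It differs from compound 2 in one place: one bromine atom in place of a group of 10 heavy atoms (7 carbon, 2 nitrogen, 1 oxygen; one six-membered aromatic ring of carbon only), on an aromatic carbon. Among the compounds with values here, the only measured step, a 1.0-fold higher number from compound 1 to compound 3 (0.02 log units; within the scatter), concerns the fluorophenyl on the sulfonyl sulfur, a different part of the molecule, so it gives no direct guidance for this change. What the values do show is that compound 1 and compound 3, which carry a smaller group at the same ring carbon, both return markedly higher numbers than compound 2. On that basis the exchange for a single bromine is expected to move compound 4 toward those higher numbers, by about a 2.3-fold higher number from compound 2 to compound 4 (0.36 log units; beyond the scatter). The estimate for compound 4 in this assay is therefore 35000 nM, with a range from 12000 nM to 100000 nM.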

Compound 4, half-maximal cytotoxic concentration: 19200 nM
Beside the measured number, compound 4's estimate is 1.8-fold (0.26 log units) above it; the range from low to high includes it.
By their numbers in this assay, from the lowest: compounds 2 and 4 (each within the scatter of the next); then compounds 1 and 3 (each within the scatter of the next).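

In this assay, replacing the group of 10 heavy atoms, with its six-membered aromatic ring, by a single bromine on the same aromatic carbon gives a 1.3-fold higher number from compound 2 to compound 4 (0.10 log units; within the scatter) and so leaves compound 2 and compound 4 indistinguishable. Within the data shown here, this is the first direct reading at this position, and for this pair the number does not follow the size of the group, even though a group carrying hydrogen-bond donors and acceptors gives way to one with none. Nothing available explains why the two compounds read alike.

Going by these compounds, whether this insensitivity extends to other groups on this carbon remains open, for instance a chlorine, an amine or a carboxylic acid. It is also unknown whether the same exchange would read alike with a different substituent on the sulfonyl sulfur.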